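The source may report more compounds than this note shows. Statements on the series, on what has been measured and on what is new or still open speak of the compounds shown alone.

Measured compounds and their numbers:
- compound 1, `CCOC(=O)CNC(=O)N1CC1C#N`: 24000 nM
- compound 2, `CCCCNC(=O)N1CC1C#N`: 18000 nM
- compound 3, `N#CC1CN1C(=O)Nc1ccc([N+](=O)[O-])cc1`: 3900 nM

All three share the same small core, a three-membered ring carrying a nitrile and a urea; they differ only in what hangs from the urea nitrogen. In a functional assay on A549 cells (Homo sapiens) for inhibition (a higher number here means a weaker inhibitor, a lower number a stronger inhibitor), compound 2 gives 18000 nM. That number sits next to the number of compound 1, close enough to count as the same within the usual scatter, while the number of compound 3 is well separated from it, beyond the scatter, in the direction of stronger inhibition.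

The next compound, compound 4, `CCNC(=O)N1CC1C#N`, shortens the chain on the urea nitrogen: hydrogen in place of ethyl on a saturated chain carbon, two bonds along the chain from an amide-type nitrogen, so that butyl becomes ethyl. Among the measured compounds shown here, no pair of measured compounds shows exactly this kind of shortening, so its effect is open. Because compound 1 gives 24000 nM and compound 2 gives 18000 nM while carrying different groups of comparable size at this position, a short alkyl chain appears to matter little here, and the step from compound 2 to compound 4 is expected to be small, if anything toward weaker inhibition, likely within the scatter: a 1.4-fold higher number from compound 2 to compound 4 (0.14 log units; within the scatter). For compound 4 the expected value in this assay is 25000 nM, with a range from 8000 nM to 80000 nM.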

Compound 4, half-maximal inhibitory concentration: 18000 nM
Estimate against measurement, compound 4: 1.4-fold (0.14 log units) above; measured number inside the range.
By their numbers in this assay, from the lowest: compound 3; then compounds 2, 4 and 1 (each within the scatter of the next).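

Cutting butyl back to ethyl leaves the number in this assay unchanged (no change at the digits printed from compound 2 to compound 4 (within the scatter)), and this is the first direct comparison of two chain lengths at this position. For this pair, the outer two carbons of the butyl chain can go without a measurable shift. Nothing available here explains this result.

Still open, as far as these compounds go, is whether a methyl group, a longer chain such as octyl, or a chain ending in an amine or a carboxylic acid would behave the same way. From the compounds shown here alone, how a plain phenyl group would compare with the group on compound 3 also remains open.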